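The source may report more compounds than this note shows. Statements on the series, on what has been measured and on what is new or still open speak of the compounds shown alone.

Measured compounds:
- compound 1 `CC1=NC(C)=C([N+](=O)[O-])C(c2ccncc2)/C1=C(\O)OC(C)(C)C`: 2820 nM
- compound 2 `CC1=NC(C)=C([N+](=O)[O-])C(c2ccncc2)/C1=C(\O)OC(C)C`: 8050 nM
- compound 3 `CCO/C(O)=C1\C(C)=NC(C)=C([N+](=O)[O-])C1c1cccnc1`: 8840 nM

Of the compounds shown here, three have been measured in a functional assay (cardiac atrium) for agonist activity, with Cavia porcellus as the target; a lower number here means that less compound is needed, a higher number that more compound is needed for the effect. Compound 1 gives 2820 nM in this assay. One change, (hydrogen in place of methyl on a saturated chain carbon bound to an oxygen on an unsaturated carbon and two saturated chain carbons), leads to compound 2, and the step of a 2.9-fold higher number from compound 1 to compound 2 (0.46 log units; beyond the scatter) moves toward a higher number. Compound 3 has a different core; how its core differs from that of compound 1 is not broken down here. In this assay compound 3 gives 8840 nM, which carries the highest number of the three, though the gap to compound 2 is within the scatter, while the gap to compound 1 is beyond it.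

Compound 4 `CO/C(O)=C1\C(C)=NC(C)=C([N+](=O)[O-])C1c1cccnc1` has not been measured. It differs from compound 3 by hydrogen in place of methyl on a saturated chain carbon bound to an oxygen on an unsaturated carbon. Among the compounds with values here, this is the same kind of change as the one from compound 1 to compound 2, not the same change: there the place was a saturated chain carbon bound to an oxygen on an unsaturated carbon and two saturated chain carbons, here it is a saturated chain carbon bound to an oxygen on an unsaturated carbon, with no further saturated chain carbons on it.

Within the data shown here, for this assay the expected step is a 1.8-fold higher number from compound 3 to compound 4 (0.26 log units; within the scatter), set at a modest size because a 2.9-fold higher number from compound 1 to compound 2 (0.46 log units; beyond the scatter) is the only measured instance of this kind of change; the difference in the surroundings of the place and the different core leave the size uncertain, so the range is kept wide. Compound 4 is expected to give about 16000 nM in this assay, estimated between 6000 nM and 40000 nM.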

Compound 4, half-maximal effective concentration: 70000 nM
Compound 4: the middle estimate sits 4.4-fold (0.64 log units) below what was measured, outside the stated range (above it).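

In this assay, the change from ethoxy to methoxy gives a 7.9-fold higher number from compound 3 to compound 4 (0.90 log units; beyond the scatter). Hydrogen in place of methyl therefore moves the number higher in both pairs shown, so the direction of the step carries from one core to the other, but its size does not: the same change on two cores in this assay, a 2.9-fold higher number (0.46 log units; beyond the scatter) from compound 1 to compound 2 and a 7.9-fold higher number (0.90 log units; beyond the scatter) from compound 3 to compound 4, 2.8-fold (0.44 log units) apart, beyond the scatter of two such steps

This does not show that the core alone sets the size, as the two steps also differ in the surroundings of the place: in one the saturated chain carbon bears two further saturated chain carbons, and in the other it bears none. With a single pair on each core, the data cannot separate these two differences, and they give no rule for carrying the change to a third core or to another place on the chain.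

As far as these compounds go, it remains open what step ethoxy to methoxy would give on the core of compound 1, which would set the same change at the same place on both cores. Also open, from the compounds shown here alone, is how the number in this assay would respond on either core to a longer chain such as butoxy, or to a chain ending in an amine or a carboxylic acid.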